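The source may hold more compounds than are shown below. What is called first, only, known or untested is meant among the compounds shown, and "the series" means these compounds.

Compound 1, `C=C[C@@](C)(/C=C/c1ccc(O)c(/C=C/c2ccc(Cl)cc2)c1)CCC=C(C)C`, gives in a functional assay on Raji cells (Homo sapiens) for cytotoxicity, with a stated time of 72 h (on this read-out higher numbers stand for an effect only at larger amounts of compound and lower numbers for an effect already at smaller amounts), only a limit, > 26000 nM.
Compound 2, `C=C[C@@](C)(/C=C/c1ccc(O)c(/C=C/c2ccc(Cl)c(Cl)c2)c1)CCC=C(C)C`, gives in this assay only a limit, > 26000 nM.
Compound 3, `C=C[C@@](C)(/C=C/c1ccc(Nc2ccc(Cl)cc2)cc1)CCC=C(C)C`, gives in this assay only a limit, > 26000 nM.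

Compound 2 differs from compound 1 by chloro in place of hydrogen on an aromatic carbon. The step that the two limits leave unreadable from compound 1 to compound 2 cannot be read as a number, since both ends sit at the limit of > 26000 nM in this assay, at which 3 of the 3 values shown sit. Compound 3 carries a different core; the difference between the two cores is not broken down here.

Compound 4, `C=C[C@@](C)(/C=C/c1ccc(Nc2ccc(Cl)c(Cl)c2)cc1)CCC=C(C)C`, has not yet been measured. It differs from compound 3 by chloro in place of hydrogen on an aromatic carbon, the same change that leads from compound 1 to compound 2.

In this assay compound 4 is expected to remain at or beyond the limit, and the step that the limit leaves unreadable from compound 3 to compound 4 is estimated as a small one. This expectation rests on compound 3 giving only a limit, > 26000 nM, and on the unreadable step that the two limits leave unreadable from compound 1 to compound 2, where the same change left both compounds at the limit of > 26000 nM in this assay, at which 3 of the 3 values shown sit. The estimate for compound 4 is 40000 nM, with a range from 15000 nM to 150000 nM.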

Compound 4, half-maximal effective concentration: > 26000 nM
Compound 4: no number, only a limit; the forecaster's own chance of this, stated with the estimate: 85%; the middle value lies beyond the limit too.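

The step from compound 3 to compound 4 cannot be read as a number, because both compounds give only a limit and no measured value: the limit of > 26000 nM in this assay, at which 4 of the 4 values shown sit.

The compounds shown leave open how far past that limit each one lies, and whether the added chloro changes the read-out in this assay on either core.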